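A cyclopropyl for the methyl on the triazole of compound 2

The compounds below may be only part of what the source reports. "The series", "measured", "known", "first", "only" and "open" are said of these compounds alone.

In a functional assay on the whole organism (strain CF-1) with Mus musculus as the target (a lower number here means that less compound is needed, a higher number that more compound is needed for the effect), compound 1 `Cc1nnc(CN(C)C)n1-c1ccccc1C(=O)c1ccccc1Cl` gives 22 mg/kg. Compound 2 `Cc1nnc(CN(C)C)n1-c1ccc(Cl)cc1C(=O)c1ccccc1Cl`, which carries a chloro in place of hydrogen on an aromatic carbon, gives 0.25 mg/kg in this assay. Going by the values given here, that single change is the only measured step, and it is large: an 88-fold lower number from compound 1 to compound 2 (1.94 log units; beyond the scatter). Among the compounds with values here, compound 2 therefore stands at the lower of the two numbers, with compound 1 the only neighbour.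

Compound 3 `CN(C)Cc1nnc(C2CC2)n1-c1ccc(Cl)cc1C(=O)c1ccccc1Cl` is not yet measured. It differs from compound 2 in one place: cyclopropyl in place of methyl on an aromatic carbon. Within the data shown here, the one measured step concerns a different position and a different kind of change, so none of the measured steps bears on this one. With nothing to carry over, the expected step in this assay from compound 2 to compound 3 is none beyond the scatter, a 1.2-fold higher number from compound 2 to compound 3 (0.08 log units; within the scatter), and the uncertainty is wide in both directions. For compound 3 the estimated value in this assay is 0.3 mg/kg, with a range from 0.08 mg/kg to 1.2 mg/kg.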

Compound 3, dose for half-maximal effect: 1.1 mg/kg
Beside the measured number, compound 3's estimate is 3.7-fold (0.56 log units) below it, within the range that was stated.
By their numbers in this assay, from the lowest: compound 2; then compound 3; then compound 1.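

Setting cyclopropyl in place of methyl on this aromatic carbon, between two ring nitrogen atoms, gives a 4.4-fold higher number from compound 2 to compound 3 (0.64 log units; beyond the scatter) in this assay, so the position responds to the change, though the step is modest. Going by these compounds alone, the earlier compounds could not show this, as their only step, an 88-fold lower number from compound 1 to compound 2 (1.94 log units; beyond the scatter), concerned a chloro at a different place and said nothing about the group on this carbon. With cyclopropyl in place of methyl, the number rises, but no measurement shown here explains this rise.

As far as these compounds go, a single change at this carbon cannot separate the effect of the added carbon atoms from that of the three-membered ring, and it remains open whether an ethyl or an isopropyl group here would give a number closer to compound 2 or to compound 3. From the compounds shown here alone, it is equally open whether the same exchange would give a step of similar size on the core of compound 1, which carries hydrogen where compound 2 carries the chloro.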